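Carbamates Against Zeta-Carotene Desaturase: A Benzyl Variant

The compounds below may be only part of what the source reports. "The series", "measured", "known", "first", "only" and "open" are said of these compounds alone.

Compound 1, `CCC(COc1cccc(OC)c1)OC(=O)NCc1ccccc1`: > 100000 nM
Compound 2, `CCC(COc1cccc(C(F)(F)F)c1)OC(=O)Nc1ccccc1`: > 100000 nM

Both compounds were tested in an assay for inhibition of zeta-carotene desaturase, chloroplastic/chromoplastic (Capsicum annuum), using a Dixon plot, with a stated time of 8 h; on this read-out lower numbers stand for stronger inhibition and higher numbers for weaker inhibition. For compound 1 the value > 100000 nM is a limit of the assay, not a number. For compound 2 the value > 100000 nM is likewise only a limit. Compound 2 thus stands at the limit together with every value shown, as the limit of > 100000 nM in this assay, at which 2 of the 2 values shown sit, records.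

Compound 3, `CCC(COc1cccc(C(F)(F)F)c1)OC(=O)NCc1cccc(Cl)c1`, differs from compound 2 in one place: 3-chlorobenzyl in place of phenyl on an amide-type nitrogen. Going by the values given here, no step between two measured compounds exists here, so there is no measured size to lean on. Compound 1 carries a benzyl group on its amide-type nitrogen and also reaches only the limit. The step from compound 2 to compound 3 is therefore expected to be none beyond the scatter, a number no higher from compound 2 to compound 3 (the limit leaves the size open). Compound 3 is expected to give 100000 nM, within 30000 nM to 300000 nM, most likely again reported as a limit.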

Compound 3, half-maximal inhibitory concentration: > 100000 nM
Compound 3 was reported as a limit; the forecaster's own chance of this, stated with the estimate: 75%; the middle value sits exactly at the limit.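

Compound 2 and compound 3 are each reported only as a limit, so no step from one to the other can be read: the limit of > 100000 nM in this assay, at which 3 of the 3 values shown sit.

The compounds shown leave open whether any change to the shared core would give an actual number, rather than a limit, in this assay.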